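Removing the para-fluorine from the aryl ring of compound 2

The compounds below may be only part of what the source reports. "The series", "measured", "known", "first", "only" and "open" are said of these compounds alone.

Compound 2 `C[C@@H](O[C@@H]1[C@@H](c2ccc(F)cc2)CN2C(=O)OC[C@@H]12)c1cc(C(F)(F)F)cc(C(F)(F)F)c1` is a close relative of compound 1 `C[C@@H](O[C@H]1CN(C(=O)OC(C)(C)C)[C@@H](CO)[C@@H]1c1ccc(F)cc1)c1cc(C(F)(F)F)cc(C(F)(F)F)c1`. In an assay on CHO cells for displacement of a labelled ligand from Substance-P receptor (Homo sapiens) (on this read-out lower numbers stand for stronger inhibition and higher numbers for weaker inhibition), compound 2 gives 0.33 nM, and compound 1 gives 0.28 nM; the two numbers sit within the usual scatter of each other, so neither is told apart from the other on this read-out. Compound 3 `C[C@@H](O[C@@H]1[C@@H](c2ccccc2)CN2C(=O)OC[C@@H]12)c1cc(C(F)(F)F)cc(C(F)(F)F)c1` differs from compound 2 by one change: hydrogen in place of fluoro on an aromatic carbon. Within the data shown here, no measured pair shows this change here. The step of a 2.1-fold higher number from compound 2 to compound 3 (0.33 log units; beyond the scatter) is estimated to be small, toward a somewhat higher number. Compound 3 is expected to give 0.7 nM, within a range from 0.25 nM to 2 nM.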

Compound 3, half-maximal inhibitory concentration: 1.3 nM
Beside the measured number, compound 3's estimate is 1.9-fold (0.27 log units) below it; low and high end bracket the measured number.
By their numbers in this assay, from the lowest: compounds 1 and 2 (each within the scatter of the next); then compound 3.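

In this assay, hydrogen in place of fluoro on the aromatic carbon gives a 3.9-fold higher number from compound 2 to compound 3 (0.60 log units; beyond the scatter), the only single-place change shown here. The fluoro at this position therefore matters on this read-out: going from 4-fluorophenyl to phenyl weakens inhibition by more than the usual scatter. Nothing at hand explains this loss. The compounds shown leave open whether chloro, methyl or methoxy on the same aromatic carbon would match fluoro, and whether the same change would act alike on the core of compound 1.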